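Quinolin-6-yl for 1H-indol-5-yl in a cytotoxic pair

The compounds below may be only part of what the source reports. "The series", "measured", "known", "first", "only" and "open" are said of these compounds alone.

In a functional assay on A549 cells (Homo sapiens) for cytotoxicity, read by MTT assay, with a stated time of 48 h (on this read-out higher numbers stand for weaker inhibition and lower numbers for stronger inhibition), compound 2 `O=C(/C=C\Nc1ccc2[nH]ccc2c1)c1c(-c2ccc(Cl)cc2)nc2ccccn12` gives 1010 nM while compound 1 `COc1ccc(-c2nc3ccccn3c2C(=O)/C=C\Nc2ccc3ncccc3c2)cc1` gives 1210 nM on the same read-out. Within the data shown here, these two values lie within the scatter of each other, so compound 2 stands level with the only other number available. Compound 3 `O=C(/C=C\Nc1ccc2ncccc2c1)c1c(-c2ccc(Cl)cc2)nc2ccccn12` departs from compound 2 at one place, with quinolin-6-yl in place of 1H-indol-5-yl on an amine nitrogen is the change awaiting its result. Among the measured compounds shown here, no measured pair isolates this swap. Compound 1 already carries quinolin-6-yl and its 1210 nM gives no sign of a shift, so no change beyond the scatter is expected in this assay here. The expected step of a 1.1-fold lower number from compound 2 to compound 3 (0.03 log units; within the scatter) is therefore small and has no firm direction. For compound 3 the estimated value is 950 nM with an expected range of 350 nM to 2800 nM in repeated measurements.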

Compound 3, half-maximal inhibitory concentration: 13000 nM
The estimate for compound 3 lay 14-fold (1.14 log units) below the measured number; measured number outside the range, above it.
By their numbers in this assay, from the lowest: compounds 2 and 1 (each within the scatter of the next); then compound 3.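

In this assay, the amine nitrogen proves sensitive to the group it carries once chloro is present on the aromatic carbon: quinolin-6-yl in place of 1H-indol-5-yl gives a 13-fold higher number from compound 2 to compound 3 (1.11 log units; beyond the scatter). Compound 1 had suggested that quinolin-6-yl could be accommodated, but that reading holds only alongside methoxy, since chloro in place of methoxy gives an 11-fold higher number from compound 1 to compound 3 (1.03 log units; beyond the scatter). The cost of quinolin-6-yl therefore depends on the group at the other place, and the two changes cannot be treated as independent on this evidence.

No measurement shown explains the weaker inhibition of compound 3. Open questions are how 1H-indol-5-yl behaves alongside methoxy, and whether a fluoro group in place of chloro, or a plain phenyl on the amine nitrogen, would follow compound 2 or compound 3.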